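This account rests on a few compounds, and the source may have more. Where it says the series, first, only, none or still open, it means among the compounds named here.

Compound 1 `O=C(Cn1nnc(-c2ccccc2)n1)NC1CC2CCC1C2` and compound 2 `Cc1cc(NC(=O)Cn2nnc(-c3ccccc3)n2)n(C2CCC(F)(F)CC2)n1` have both been measured in an assay on HEK293 cells for activation of Kir3.1/Kir3.2 (Homo sapiens), read by thallium flux; a higher number here means a larger maximal response, a lower number a smaller maximal response. In this assay compound 1 reaches 13%, whereas compound 2 reaches 68%, the higher of the two numbers and a gap beyond the usual scatter. Among the compounds with values here, compound 1 and compound 2 differ in more than one place, so no step between compounds differing in a single place is available, and the effect of any one change on the maximal response is not yet known. Compound 3 `Cc1cc(NC(=O)Cn2nnc(-c3ccccc3)n2)n(C2CC2)n1` differs from compound 2 in one place (cyclopropyl in place of 4,4-difluorocyclohexyl on an aromatic nitrogen). With no step of this kind measured, the expectation rests only on the two numbers shown. Compound 3 is expected to give a smaller maximal response than compound 2 in this assay, a step of a number 23 percentage points lower from compound 2 to compound 3 (beyond the scatter) that would probably lie beyond the scatter. The estimate for compound 3 in this assay is 45%, with a range from 20% to 70%.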

Compound 3, largest response reached (Emax), in percent of the reference or control that the assay uses: > 78%
Compound 3: a limit, no number (the forecaster's own chance of this, stated with the estimate: 0%); at least 33 percentage points between middle value and limit.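

On the aromatic nitrogen, the change to cyclopropyl in place of 4,4-difluorocyclohexyl gives, in this assay, a number at least 10 percentage points higher from compound 2 to compound 3 (that floor lies within the scatter). The reading for compound 3 is a limit of the assay and not a number: the limit of > 78% in this assay, at which 1 of the 3 values shown sits. The position therefore does not need the six-membered ring or its fluorine for a large maximal response, since a three-membered ring of carbon alone, with 3 heavy atoms in place of 8, loses none of the response that compound 2 shows.

The limit leaves the true size of this step unknown. Going by these compounds, how far this position tolerates other groups also stays open: an open chain such as n-butyl, a group bearing an amine such as 2-aminoethyl, or a plain hydrogen on that nitrogen could each behave differently.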